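Ring-nitrogen substituent swap in a growth-inhibition series

The source may hold more compounds than are shown below. What is called first, only, known or untested is meant among the compounds shown, and "the series" means these compounds.

Measured so far:
compound 1, `Cc1ccc(S(=O)(=O)Nc2ccc(CNC(=O)CC3c4ccccc4N=C(N4CCCCC4)N3c3ccccc3)cc2)cc1`: 3060 nM
compound 2, `COC(=O)CC1c2ccccc2N=C(NCCCCCN)N1c1ccc(-c2ccccc2)cc1`: 3390 nM

Both numbers come from a functional assay on A549 cells (Homo sapiens) for inhibition, read by sulforhodamine B assay; on this read-out lower numbers stand for stronger inhibition of growth and higher numbers for weaker inhibition of growth. For the measured compounds named here, compound 1 and compound 2 lie within the usual scatter of each other, so the two cannot be separated on these data; no step between compounds differing in one place has been measured.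

Compound 3 `CCN1C(N2CCCCC2)=Nc2ccccc2C1CC(=O)NCc1ccc(NS(=O)(=O)c2ccc(C)cc2)cc1` differs from compound 1 by ethyl in place of phenyl on an amine nitrogen in a ring. Going by the values given here, with no measured step of this kind to lean on, the change is expected to move the number at most a little, probably toward weaker inhibition, or not beyond the scatter. Compound 3 is expected at 4500 nM in this assay, in the range 1500 nM to 15000 nM. The expected step of a 1.5-fold higher number from compound 1 to compound 3 (0.17 log units; within the scatter) is estimated to be small.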

Compound 3, concentration for 50% growth inhibition: 23000 nM
The estimate for compound 3 lay 5.1-fold (0.71 log units) below the measured number; the whole stated range lies below it.
By their numbers in this assay, from the lowest: compounds 1 and 2 (each within the scatter of the next); then compound 3.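

For the compounds shown here, on the amine nitrogen in the ring, ethyl in place of phenyl gives a 7.5-fold higher number from compound 1 to compound 3 (0.88 log units; beyond the scatter) in this assay and is the first single-place step, so this position is not indifferent to its substituent. With the rest of compound 1 unchanged, the weaker inhibition tracks this one swap. Nothing on hand accounts for the shift. On these data alone, whether the aromatic ring or only the carbon count matters stays open: cyclohexyl, benzyl or a longer chain such as butyl on this nitrogen would separate the two readings.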